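Tolerance on colon cells across a urea-linked benzothiazole series

A few compounds are considered here, and "the series" means these few. Any claim that something is new, unique, unknown or untested is made for them only; others in the source may bear on it.

Compound 1 `Cc1cccc(NC(=O)Nc2cc(Oc3ccc4nc(NC(=O)C5CC5)sc4c3)ccc2F)c1`: > 50000 nM
Compound 2 `COc1cccc(NC(=O)Nc2cc(Oc3ccc4nc(NC(=O)C5CC5)sc4c3)ccc2F)c1`: > 50000 nM
Compound 3 `O=C(Nc1nc2ccc(Oc3ccc(F)c(NCc4cccc(C(F)(F)F)c4)c3)cc2s1)C1CC1`: "not determined" (no result reported)

In an ADME assay on HT-29 cells (Homo sapiens) for cytotoxicity, read by luminescence and CellTiter-Glo, with a stated time of 12 h (a higher number here means that more compound is tolerated, a lower number that less compound is tolerated), compound 1 gives > 50000 nM, which is a limit of the assay and not a number. Compound 2 gives > 50000 nM, again a limit. The change from a methyl to a methoxy group on the aromatic carbon therefore yields a step that the two limits leave unreadable from compound 1 to compound 2, and nothing about its size can be read, since (the limit of > 50000 nM in this assay, at which 2 of the 3 values shown sit).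

Compound 3 stands apart: in this assay compound 3 gives "not determined" (no result reported), so no value places it on the scale at all.

Compound 4 `CC(=O)c1cccc(NC(=O)Nc2cc(Oc3ccc4nc(NC(=O)C5CC5)sc4c3)ccc2F)c1` differs from compound 3 by (3-acetylphenyl)carbamoyl in place of 3-(trifluoromethyl)benzyl on a nitrogen on an aromatic ring. That change brings compound 4 back to the urea pattern shared by compound 1 and compound 2. Among the compounds with values here, the only measured step, from compound 1 to compound 2, is unreadable, so no size or direction for a step can be drawn from it; the expectation for compound 4 rests instead on the fact that both of its closest relatives sit at the limit of > 50000 nM in this assay, at which 2 of the 3 values shown sit.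

Compound 4 is therefore expected to give about 50000 nM in this assay, within a range from 20000 nM to 100000 nM, and most likely to be reported only as a limit.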

Compound 4, half-maximal cytotoxic concentration: > 50000 nM
Compound 4: no number, only a limit; the forecaster's own chance of this, stated with the estimate: 80%; the middle value sits exactly at the limit.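

Compound 4, like compound 1 and compound 2, gives a limit of the assay and not a number, so no step among these three compounds can be read: the limit of > 50000 nM in this assay, at which 3 of the 4 values shown sit.

The compounds shown leave open how much of compound 1, compound 2 or compound 4 is tolerated in this assay, and where compound 3 stands on that scale.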